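Swapping the side group of compound 1

The source may hold more compounds than are shown below. What is called first, only, known or untested is meant among the compounds shown, and "the series" means these compounds.

In a functional assay on A549 cells (Homo sapiens) for cytotoxicity, read by MTT assay, with a stated time of 48 h (on this read-out higher numbers stand for weaker inhibition and lower numbers for stronger inhibition), compound 1 `COc1c(OCc2cnoc2C)cc(O)c2c(=O)cc(-c3ccccc3)oc12` gives > 100000 nM, which is a limit of the assay and not a number. The other two compounds tested offer no comparison. For compound 2 `O=c1cc(-c2ccccc2)oc2c(OCCCCNC3CCCCC3)c(O)cc(O)c12` the entry reads "not determined" (no result reported). For compound 3 `COc1c(O)cc(O)c2c(=O)cc(-c3ccc(Cl)cc3)oc12` the entry reads "not determined" (no result reported). Among the compounds with values here, no step between measured compounds therefore exists, and the shared core has no numerical trend to draw on.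

Compound 4 `COc1c(OCCCN2CCN(C)CC2)cc(O)c2c(=O)cc(-c3ccccc3)oc12` has not yet been measured. It differs from compound 1 in a single place: 2-(4-methylpiperazin-1-yl)ethyl in place of 5-methyl-1,2-oxazol-4-yl on a saturated chain carbon bound to an oxygen on an aromatic ring. In words, 2-(4-methylpiperazin-1-yl)ethyl stands in place of 5-methyl-1,2-oxazol-4-yl on a saturated chain carbon bound to an oxygen on an aromatic ring. Cut one bond further out, the same change reads (5-methyl-1,2-oxazol-4-yl)methyl to 3-(4-methylpiperazin-1-yl)propyl.

With only the reading for compound 1 at > 100000 nM as an anchor, any expected movement in this assay can run only toward stronger inhibition, and a modest move is the cautious expectation, with a real chance that another limit is reported. The expected size is an at least 3.3-fold lower number from compound 1 to compound 4 (0.52 log units; beyond the scatter), an estimate and nothing firmer. For compound 4 the estimated value is 30000 nM, with an expected range of 8000 nM to 100000 nM.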

Compound 4, half-maximal inhibitory concentration: 9900 nM
Compound 4: middle estimate off by 3.0-fold (0.48 log units), on the high side; measured number inside the range.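

Within the data shown here, the change at this position, on a saturated chain carbon bound to an oxygen on an aromatic ring, gives the only step that can be read in this assay: 2-(4-methylpiperazin-1-yl)ethyl in place of 5-methyl-1,2-oxazol-4-yl yields an at least 10-fold lower number from compound 1 to compound 4 (1.00 log units; beyond the scatter). Among these compounds, the side group at this place alone is thus enough to take the read-out from a limit to a measured number, which no earlier compound could show. The step gives only a minimum size and not an exact one, because compound 1 gives no number to start from: the limit of > 100000 nM in this assay, at which 1 of the 4 values shown sits.

The compounds shown do not separate the parts of the change, since the ring, the chain and the two nitrogens all enter together, so it stays open which of them carries the step. As far as these compounds go, whether a morpholine ring on the same chain, a simple dimethylamino group or a longer chain ending in the same 4-methylpiperazine would give a lower or a higher number in this assay also remains open.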